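The source may hold more compounds than are shown below. What is called first, only, known or untested is meant among the compounds shown, and "the series" means these compounds.

Measured so far in an ADME assay on microsomes from liver (Homo sapiens) for metabolic stability, with a stated time of 10 min, tested at 0.5 uM; a higher number here means that more of the compound is left, a lower number that less of the compound is left:
- compound 1 `CCc1noc(C)c1[C@@H]1C[C@@](C)(c2ccc(F)cc2F)N=C(N)S1`: 21%
- compound 2 `Cc1noc(C(F)F)c1[C@@H]1C[C@@](C)(c2ccc(F)cc2F)N=C(N)S1`: 35%

Of these two, compound 2 stands higher at 35%, and its gap to compound 1 at 21% lies beyond the scatter. Compound 3 `Cc1nocc1[C@@H]1C[C@@](C)(c2ccc(F)cc2F)N=C(N)S1` remains unmeasured. Its structure differs from that of compound 2 by hydrogen in place of difluoromethyl on an aromatic carbon, with hydrogen in place of difluoromethyl on an aromatic carbon. Within the data shown here, no measured pair isolates this change, so the expectation is loose: a small rise in this assay, probably not beyond the scatter. The estimated change is a number 5 percentage points higher from compound 2 to compound 3 (within the scatter). The expected value for compound 3 is 40%, within an estimated range of 22% to 60%.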

Compound 3, percent of the compound remaining: 65%
Beside the measured number, compound 3's estimate is 25 percentage points below it; the whole stated range lies below it.
By their numbers in this assay, from the lowest: compound 1; then compound 2; then compound 3.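

Among these compounds, on the aromatic carbon next to the ring oxygen, hydrogen in place of difluoromethyl gives a number 30 percentage points higher from compound 2 to compound 3 (beyond the scatter) in this assay, the first step that isolates this position, and the unsubstituted carbon gives the better result of this pair. The step of a number 44 percentage points higher from compound 1 to compound 3 (beyond the scatter) changes two places at once, so it does not separate the ethyl-to-methyl change from the loss of the methyl on the aromatic carbon. Nothing available explains the size of either step. From the compounds shown here alone, whether a chlorine, a methoxy group or an amine on this carbon stays nearer compound 2 or compound 3 remains open.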